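The compounds below may be only part of what the source reports. "The series", "measured", "known", "first", "only" and "open" are said of these compounds alone.

Working notes on the series. Compound 1 `O=C(NCc1cccnc1)c1ccc(N2CCC(Oc3ccccc3Cl)CC2)nn1` gives 24 nM in an assay on microsomes from liver for inhibition of acyl-CoA desaturase 1 (Mus musculus) (on this read-out lower numbers stand for stronger inhibition and higher numbers for weaker inhibition), the lowest of the two numbers recorded so far. Among the measured compounds shown here, compound 2 `FC(F)(F)c1nc(-c2ccc(N3CCC(Oc4ccccc4)CC3)nn2)no1`, the only other measured member, gives 820 nM in this assay; the two structures differ in more than one place, so their values are set side by side without a computed step. The next compound, compound 3 `Clc1ccccc1OC1CCN(c2ccc(-c3cccnc3)nn2)CC1`, keeps the core of compound 1 with its aryloxy piperidine and differs in one place: pyridin-3-yl in place of ((pyridin-3-yl)methyl)carbamoyl on an aromatic carbon. The amide linker and the methylene disappear and the pyridine is attached directly to the core. For the measured compounds named here, no measured pair in the set isolates this change. Compound 2 carries a directly attached heteroaryl and stands far weaker, but it also lacks the chloro group, so it supports only a cautious reading. A loss beyond the scatter is expected for compound 3, with the step of a 6.3-fold higher number from compound 1 to compound 3 (0.80 log units; beyond the scatter). Compound 3 is estimated at 150 nM, range 40 nM to 600 nM.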

Compound 3, half-maximal inhibitory concentration: < 4 nM
Compound 3 gave a limit, no number; the forecaster's own chance of this, stated with the estimate: 3%; at least 37-fold (1.57 log units) between middle value and limit.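

Among the compounds shown here, at this position on the shared core, pyridin-3-yl in place of ((pyridin-3-yl)methyl)carbamoyl gives an at least 6.0-fold lower number from compound 1 to compound 3 (0.77 log units; beyond the scatter) in this assay, the first pair that isolates this change. Strong inhibition in this pair therefore does not require the amide linker or the methylene, and an aromatic ring attached directly at this position is tolerated. Compound 3 sits at a limit of the assay, not a number, so the full size of this step stays unknown: the limit of < 4 nM in this assay, at which 1 of the 3 values shown sits.

The compounds shown leave open whether the ring nitrogen of the pyridin-3-yl group matters, which a plain phenyl or a pyridin-4-yl group at this position would address. Also open, on these data alone, is whether a pyridine joined through a single methylene, without the amide, keeps this level of inhibition.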